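Methoxy additions on the chalcone series against p65

The source may report more compounds than this note shows. Statements on the series, on what has been measured and on what is new or still open speak of the compounds shown alone.

Compound 2 `COc1ccccc1/C=C/C(=O)c1cccc(-c2cccc(F)c2)c1` carries a 2-methoxyphenyl on the double-bonded chain carbon; in an assay on A549 cells for inhibition of transcription factor p65 (Homo sapiens), read by fluorescence, with a stated time of 2 h (on this read-out lower numbers stand for stronger inhibition and higher numbers for weaker inhibition), compound 2 gives 35300 nM. Compound 1 `COc1cccc(/C=C/C(=O)c2cccc(-c3cccc(F)c3)c2)c1OC` adds a methoxy methoxy in place of hydrogen on an aromatic carbon and in this assay compound 1 gives 24100 nM, a step of a 1.5-fold lower number from compound 2 to compound 1 (0.17 log units; within the scatter). Compound 3 `COc1ccc(/C=C/C(=O)c2cccc(-c3cccc(F)c3)c2)cc1` differs from compound 2 in the core (4-methoxyphenyl in place of 2-methoxyphenyl on a double-bonded chain carbon bound to a double-bonded chain carbon). In this assay compound 3 reaches only the limit > 50000 nM. The step from compound 2 to compound 3 is an at least 1.4-fold higher number from compound 2 to compound 3 (0.15 log units; that floor lies within the scatter).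

Compound 4 `COc1ccc(/C=C/C(=O)c2cccc(-c3cccc(F)c3)c2)cc1OC` is not yet measured. It relates to compound 3 as compound 1 relates to compound 2, by the same change (methoxy in place of hydrogen on an aromatic carbon), and the place descriptions agree word for word. The earlier instance gave a 1.5-fold lower number from compound 2 to compound 1 (0.17 log units; within the scatter), within the scatter, so the expected step from compound 3 to compound 4 in this assay is about a number no higher from compound 3 to compound 4 (the limit leaves the size open), which is a small move resting on that one pair. Because compound 3 sits at the limit of > 50000 nM in this assay, at which 1 of the 3 values shown sits, compound 4 may also be reported as a limit. Compound 4 is estimated at 50000 nM, between 25000 nM and 120000 nM.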

Compound 4, half-maximal inhibitory concentration: 33400 nM
The estimate for compound 4 lay 1.5-fold (0.18 log units) above the measured number; measured number inside the range.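

Methoxy in place of hydrogen on an aromatic carbon, here ortho to a methoxy group, gives an at least 1.4-fold lower number from compound 3 to compound 4 (0.17 log units; that floor lies within the scatter) in this assay. Compound 3 stands at a limit, > 50000 nM, and not at a number. Neither instance of the change is printed as beyond the scatter, so the two cores are compatible with a shared small effect, but this does not establish a real gain on either core or fix the size of the step on the core of compound 3: the same change on two cores in this assay, a 1.5-fold lower number (0.17 log units; within the scatter) from compound 2 to compound 1 and an at least 1.4-fold lower number (0.17 log units; that floor lies within the scatter) from compound 3 to compound 4; the limit leaves it open whether they differ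

Going by these compounds, all the aromatic substituents varied here are methoxy groups, so it stays open whether a hydroxy group, an amine or a carboxylic acid in the same place would move the number beyond the scatter. All four compounds also keep the same fluorine-bearing side of the molecule, and whether the change carries over when that fluorine gives way to a chlorine or a nitrile is equally unanswered.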